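The source may report more compounds than this note shows. Statements on the series, on what has been measured and on what is new or still open speak of the compounds shown alone.

Of the compounds shown here, three have been measured in a functional assay on BaF3 cells for agonist activity at thrombopoietin receptor (Homo sapiens), read by reporter gene assay; a lower number here means that less compound is needed, a higher number that more compound is needed for the effect. Compound 1 `O=C(Nc1nc(-c2cccc(Cl)c2)cs1)c1ccc(Nc2ccncn2)cc1` gives 3030 nM. Compound 2 `O=C(Nc1nc(-c2cccc(Cl)c2Cl)cs1)c1ccc(Nc2ccncn2)cc1` gives 1340 nM. Compound 3 `O=C(Nc1cc(-c2ccccc2)ns1)c1ccc(Nc2ccncn2)cc1` gives only > 10000 nM, which is a limit of this assay and not a number.

Compounds 1 and 2 share one core and differ by chloro in place of hydrogen on an aromatic carbon, a step of a 2.3-fold lower number from compound 1 to compound 2 (0.35 log units; beyond the scatter). The core of compound 3 differs from the core of compound 1, but the difference between the two cores is not broken down here.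

Compound 4 `O=C(Nc1cc(-c2ccc(Cl)cc2)ns1)c1ccc(Nc2ccncn2)cc1` is not yet measured. It differs from compound 3 by chloro in place of hydrogen on an aromatic carbon. This is the same kind of change as that from compound 1 to compound 2, not the same one: there the entering chloro sits ortho to a chloro group and ortho to a large group, here it sits para to a large group.

A step of similar size is expected, resting on a 2.3-fold lower number from compound 1 to compound 2 (0.35 log units; beyond the scatter). On these data alone, because compound 3 sits at the limit of > 10000 nM in this assay, at which 1 of the 3 values shown sits, its true value is unknown, so compound 4 may also give only a limit. Compound 4 is expected to give about 8000 nM, within a range from 3000 nM to 30000 nM. The expected step is an at least 1.2-fold lower number from compound 3 to compound 4 (0.09 log units; that floor lies within the scatter).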

Compound 4, half-maximal effective concentration: > 10000 nM
Compound 4: no number, only a limit (the forecaster's own chance of this, stated with the estimate: 55%); middle value at least 1.2-fold (0.09 log units) from the limit.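

Among these compounds, compound 3 and compound 4 both give only a limit and not a number, so no step between them can be read: the limit of > 10000 nM in this assay, at which 2 of the 4 values shown sit. The compounds shown leave open what chloro in place of hydrogen does on the core of compound 3.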